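Aryl swap on the ring amine nitrogen: compound 1 to compound 3

The source may hold more compounds than are shown below. What is called first, only, known or untested is meant among the compounds shown, and "the series" means these compounds.

Two compounds of the series carry numbers in a functional assay on HL-60 cells (Homo sapiens) for inhibition, read by MTT assay, with a stated time of 72 h; a lower number here means a stronger inhibitor, a higher number a weaker inhibitor. Compound 1 `Cc1nc(-c2ccccc2)c(C(=O)N2CCN(c3cccc(C(N)=O)c3)CC2)o1` gives 71 nM, the lowest of the two numbers; the nearest is compound 2 `Cc1nc(-c2cccc(O)c2)c(C(=O)N2CCN(c3cccc(Cl)c3)CC2)o1`, which gives 105 nM, a gap within the scatter, so the two are not separated by these data. Compound 3 `Cc1nc(-c2ccccc2)c(C(=O)N2CCN(c3ccccc3Cl)CC2)o1` has not been measured in this assay. Relative to compound 1 the change is 2-chlorophenyl in place of 3-carbamoylphenyl on an amine nitrogen in a ring. For the measured compounds named here, no pair of measured compounds differs in this one place alone, so no measured step shows the size of such a change; compound 2 differs from compound 1 in two places at once and is only loose guidance. The step of a 2.1-fold higher number from compound 1 to compound 3 (0.32 log units; beyond the scatter) is expected to be small, toward a somewhat higher number, about at the edge of the scatter. For compound 3 the estimated value is 150 nM, with a range from 50 nM to 500 nM.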

Compound 3, half-maximal inhibitory concentration: 124 nM
Estimate against measurement, compound 3: 1.2-fold (0.08 log units) above, within the range that was stated.
By their numbers in this assay, from the lowest: compounds 1, 2 and 3 (each within the scatter of the next).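

In this assay this position now has its first measured step, a 1.7-fold higher number from compound 1 to compound 3 (0.24 log units; within the scatter), so the swap to 2-chlorophenyl on the amine nitrogen in the ring does not separate the two compounds. In this one pair, the hydrogen-bond donor and acceptor counted on 3-carbamoylphenyl are absent from 2-chlorophenyl without a step beyond the scatter, although the pair alone cannot show how far that holds for other aryl groups. No measurement of any property of these groups accompanies the result.

The compounds shown leave open whether a carboxylic acid or a primary amine in place of the carbamoyl group would give a larger step. They also leave open how an unsubstituted phenyl or a benzyl group on this nitrogen would compare.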